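This account rests on a few compounds, and the source may have more. Where it says the series, first, only, none or still open, it means among the compounds named here.

Measured compounds:
Compound 1, `C[C@H](NC(=O)C(=O)NCc1ccc(Cl)cc1)C(=O)N[C@@H](CC(=O)O)C(=O)COc1c(F)c(F)cc(F)c1F`: 8.4 nM
Compound 2, `C[C@H](NC(=O)C(=O)NCC1CCCCC1)C(=O)N[C@@H](CC(=O)O)C(=O)COc1c(F)c(F)cc(F)c1F`: 19 nM
Compound 3, `C[C@H](NC(=O)C(=O)NCc1cc(Cl)ccc1Cl)C(=O)N[C@@H](CC(=O)O)C(=O)COc1c(F)c(F)cc(F)c1F`: 4.3 nM

In a functional assay on Jurkat cells (Homo sapiens) (a higher number here means a weaker inhibitor, a lower number a stronger inhibitor), compound 1 gives 8.4 nM, the second highest of the three numbers. Compound 3 gives 4.3 nM, and the step from compound 1 to compound 3 is a 2.0-fold lower number from compound 1 to compound 3 (0.29 log units; within the scatter). Compound 2 gives 19 nM, and the step from compound 1 to compound 2 is a 2.3-fold higher number from compound 1 to compound 2 (0.35 log units; beyond the scatter).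

Compound 4, `C[C@H](NC(=O)C(=O)NCc1cc(Cl)cc(Cl)c1)C(=O)N[C@@H](CC(=O)O)C(=O)COc1c(F)c(F)cc(F)c1F`, has not yet been measured in this assay. It differs from compound 1 in one place: 3,5-dichlorophenyl in place of 4-chlorophenyl on a saturated chain carbon bound to an amide-type nitrogen. Within the data shown here, the step that bears most closely on this change is the one from compound 1 to compound 3, where a second chlorine also enters on the same phenyl ring, though on a different pair of positions; that step was a 2.0-fold lower number from compound 1 to compound 3 (0.29 log units; within the scatter). The change from cyclohexyl to a chlorinated phenyl, a 4.4-fold lower number from compound 2 to compound 3 (0.65 log units; beyond the scatter), shows the chlorinated rings give the lower numbers here. A second chlorine on the ring is therefore expected to leave the number where it is or lower it slightly, within or just at the edge of the scatter.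

Compound 4 is expected to give 6 nM, with a range from 2.5 nM to 15 nM, a step of a 1.4-fold lower number from compound 1 to compound 4 (0.15 log units; within the scatter).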

Compound 4, half-maximal inhibitory concentration: 23 nM
Compound 4: the middle estimate sits 3.8-fold (0.58 log units) below what was measured; measured number outside the range, above it.
By their numbers in this assay, from the lowest: compounds 3 and 1 (each within the scatter of the next); then compounds 2 and 4 (each within the scatter of the next).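

In this assay, a second chlorine brings no gain by its presence alone: 3,5-dichlorophenyl in place of 4-chlorophenyl gives a 2.7-fold higher number from compound 1 to compound 4 (0.44 log units; beyond the scatter), and exchanging one dichlorophenyl for the other, with the same atoms, gives a 5.3-fold higher number from compound 3 to compound 4 (0.73 log units; beyond the scatter), so at this position where the chlorines sit matters as well as how many there are. A chlorinated ring also does not always outperform a saturated one: cyclohexyl to 3,5-dichlorophenyl is a 1.2-fold higher number from compound 2 to compound 4 (0.08 log units; within the scatter), so these two groups cannot be told apart here. Nothing available here accounts for the effect of the chlorine arrangement.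

On these data alone, whether bromine atoms or methoxy groups in place of the chlorines would follow the same pattern stays open. So does whether a pyridine ring in place of the phenyl, or a longer chain in place of the benzyl link, would keep these differences.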